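Swapping the aryl group on a pyrazoline thiourea series

A few compounds are considered here, and "the series" means these few. Any claim that something is new, unique, unknown or untested is made for them only; others in the source may bear on it.

Three close analogues share one core: compound 1 `Fc1ccc(C2=NN(C(=S)Nc3ccccc3)C(c3ccc4c(c3)OCCO4)C2)cc1`, compound 2 `Cc1ccc(C2=NN(C(=S)Nc3ccccc3)C(c3ccc4c(c3)OCCO4)C2)cc1` and compound 3 `COc1ccccc1C1=NN(C(=S)Nc2ccccc2)C(c2ccc3c(c2)OCCO3)C1`. In a functional assay on HT-29 cells (Homo sapiens) for antiproliferative activity, read by MTT assay, with a stated time of 48 h (on this read-out higher numbers stand for weaker inhibition of growth and lower numbers for stronger inhibition of growth), compound 1 gives 37600 nM, compound 2 gives 19500 nM and compound 3 gives 30500 nM. Compound 3 thus holds the second highest number of the three, closest to compound 1 and furthest from compound 2, though every gap among them lies within the scatter.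

Compound 4 `S=C(Nc1ccccc1)N1N=C(c2cccc(Cl)c2)CC1c1ccc2c(c1)OCCO2` differs from compound 3 in a single respect: 3-chlorophenyl in place of 2-methoxyphenyl on a carbon with a double bond to nitrogen. The measured steps that touch this position are the aryl swaps on the same carbon, a 1.2-fold lower number from compound 1 to compound 3 (0.09 log units; within the scatter) and a 1.6-fold higher number from compound 2 to compound 3 (0.19 log units; within the scatter), and the substituent swap on that aryl ring, a 1.9-fold lower number from compound 1 to compound 2 (0.29 log units; within the scatter). None of them moved this assay beyond the scatter, so the replacement of one aryl group by another at this carbon has so far made no clear difference in either direction.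

On that basis compound 4 is expected to sit close to compound 3, with the estimated step of a 1.2-fold lower number from compound 3 to compound 4 (0.07 log units; within the scatter) reflecting no change beyond the scatter. Compound 4 is therefore estimated at 26000 nM, within a range from 9000 nM to 75000 nM.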

Compound 4, concentration for 50% growth inhibition: > 200000 nM
Compound 4: only a limit was reported; the forecaster's own chance of this, stated with the estimate: 10%; at least 7.6-fold (0.88 log units) between middle value and limit.
By their numbers in this assay, from the lowest: compounds 2, 3 and 1 (each within the scatter of the next). At a limit, above all of these: compound 4.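

In this assay, the aryl group on the carbon with a double bond to nitrogen now makes a clear difference, which none of the earlier swaps showed: 3-chlorophenyl gives an at least 6.5-fold higher number from compound 3 to compound 4 (0.81 log units; beyond the scatter), an at least 10-fold higher number from compound 2 to compound 4 (1.01 log units; beyond the scatter) and an at least 5.3-fold higher number from compound 1 to compound 4 (0.72 log units; beyond the scatter). Compound 4 is reported only as a limit and not as a number: the limit of > 200000 nM in this assay, at which 1 of the 4 values shown sits. Of the four aryl groups shown, only 3-chlorophenyl separates from the others, and it does so towards weaker inhibition of growth, while 4-fluorophenyl, 4-methylphenyl and 2-methoxyphenyl stay within the scatter of each other.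

The compounds shown leave open whether the chlorine itself or its place on the ring goes with this step, and so whether 4-chlorophenyl would read like 3-chlorophenyl or like 4-fluorophenyl, and whether 3-methylphenyl or 3-methoxyphenyl would part from the series in the same way. They also leave open how an amine or a carboxylic acid on this aryl ring would read at the same carbon.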